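The compounds below may be only part of what the source reports. "The series", "measured", "known", "first", "only" and "open" are said of these compounds alone.

Measured compounds:
Compound 1, `O=C1Nc2ccc(Cl)cc2/C1=C/c1cccc(OCc2cn(Cc3ccccc3)nn2)c1`, in a functional assay on BT-549 cells (Homo sapiens) for inhibition, read by MTT assay, with a stated time of 48 h; a higher number here means a weaker inhibitor, a lower number a stronger inhibitor: "not determined" (no result reported).
Compound 2, `O=C1Nc2ccc([N+](=O)[O-])cc2/C1=C\c1cccc(OCc2cn(Cc3ccccc3)nn2)c1`, in this assay: > 50000 nM, a limit of the assay.

Compound 1 carries no result in this assay. Compound 2 gives only a limit, > 50000 nM, which says that the assay reports no number for it; this is the limit of > 50000 nM in this assay, at which 1 of the 2 values shown sits, so compound 2 stands at the weak end of what the assay can show. Compound 3, `CC(=O)c1ccc2c(c1)/C(=C\c1cccc(OCc3cn(Cc4ccccc4)nn3)c1)C(=O)N2`, has not yet been measured in this assay. It differs from compound 2 in one place: acetyl in place of nitro on an aromatic carbon. Among the measured compounds shown here, no step between two measured compounds exists here, so the data give no direction for this change. Compound 3 is therefore expected to stay near the limit, with a step of an at least 1.2-fold lower number from compound 2 to compound 3 (0.09 log units; that floor lies within the scatter) that is estimated to be small and might lie within the scatter in either direction. For compound 3 the estimate in this assay is 40000 nM, expected to fall between 5000 nM and 200000 nM.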

Compound 3, half-maximal inhibitory concentration: > 50000 nM
Compound 3: a limit, no number; the forecaster's own chance of this, stated with the estimate: 55%; middle value at least 1.2-fold (0.09 log units) away from the limit.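

In this assay compound 3 gives > 50000 nM as a limit, not a number. With compound 2 also at a limit, no step can be read between compound 2 and compound 3 for acetyl in place of nitro: the limit of > 50000 nM in this assay, at which 2 of the 3 values shown sit. The compounds shown leave open whether acetyl and nitro differ at all in this assay and, if so, by how much.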